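The source may report more compounds than this note shows. Statements on the series, on what has been measured and on what is new or still open speak of the compounds shown alone.

Measured in a functional assay on A549 cells (Homo sapiens) for cytotoxicity, read by MTT assay, with a stated time of 72 h; a higher number here means a weaker inhibitor, a lower number a stronger inhibitor:
- compound 1 `CNC(=O)c1cc(Oc2ccc(C(=O)/C=C/c3ccc(F)cc3Cl)cc2)ccn1` gives 21100 nM
- compound 2 `CNC(=O)c1cc(Oc2ccc(/C=C/C(=O)c3ccc(Br)cc3)cc2)ccn1` gives 20100 nM

Only these two compounds have been measured so far. Compound 1 at 21100 nM and compound 2 at 20100 nM lie within the usual scatter of each other, so the numbers do not separate them. Both sit in the same weak range of this assay, and compound 1 stands level with compound 2.

The next compound, compound 3 `CNC(=O)c1cc(Oc2ccc(C(=O)/C=C/c3cccc(Cl)c3Cl)cc2)ccn1`, departs from compound 1 at a single place. It has 2,3-dichlorophenyl in place of 2-chloro-4-fluorophenyl on a double-bonded chain carbon bound to a double-bonded chain carbon. Among the compounds with values here, the data hold no measured step between compounds differing in one place, so nothing direct shows how much such a swap matters. Within the data shown here, the only guide is the close agreement of the two values. No change beyond the scatter is therefore expected in this assay, in either direction.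

The expected step is a 1.2-fold lower number from compound 1 to compound 3 (0.07 log units; within the scatter). For compound 3 the estimated value is 18000 nM, with an expected range from 8000 nM to 40000 nM.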

Compound 3, half-maximal inhibitory concentration: > 50000 nM
Compound 3 gave a limit, no number; the forecaster's own chance of this, stated with the estimate: 15%; at least 2.7-fold (0.44 log units) between middle value and limit.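

Within the data shown here, the step of an at least 2.3-fold higher number from compound 1 to compound 3 (0.37 log units; beyond the scatter) gives the first evidence from a change in one place, since compound 1 and compound 2 differ in more than one place and their agreement could not show how much this position matters. In this assay compound 3 gives > 50000 nM, which is a limit of the assay and not a number, so the swap of 2-chloro-4-fluorophenyl for 2,3-dichlorophenyl on a double-bonded chain carbon bound to a double-bonded chain carbon moves the result towards weaker inhibition by an amount that has only a lower bound: the limit of > 50000 nM in this assay, at which 1 of the 3 values shown sits. The position is therefore not indifferent to the ring it carries, even though the two groups match in heavy atom count, both are a single six-membered aromatic ring of carbon only, and neither has any hydrogen-bond donors or acceptors.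

The compounds shown do not tell whether the change follows from the fluorine that leaves or the chlorine that enters. They also leave open how a phenyl ring carrying a methoxy group or an amine would fare at this place.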